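Swapping a Thiazole for an Oxazole in an Oxytocin Ligand

A few compounds are considered here, and "the series" means these few. Any claim that something is new, unique, unknown or untested is made for them only; others in the source may bear on it.

Of the compounds shown here, two built on one shared core have been measured in an assay on isolated protein for binding affinity to Oxytocin receptor (Homo sapiens); a lower number here means a stronger inhibitor, a higher number a weaker inhibitor. Compound 1 `CC(C)C[C@@H]1C(=O)N[C@H](C2Cc3ccccc3C2)C(=O)N1[C@@H](C(=O)NC(C)(C)C)c1ccoc1` gives 12.6 nM in this assay. Compound 2 `Cc1nc([C@H](C(=O)N(C)C)N2C(=O)[C@@H](C3Cc4ccccc4C3)NC(=O)[C@H]2CC(C)C)cs1` gives 0.398 nM in this assay. Of the two numbers, compound 2 holds the lower one, and its distance from compound 1 lies beyond the usual scatter of repeated measurements, so on these two results compound 2 is the stronger binder.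

Compound 3 `Cc1nc([C@H](C(=O)N(C)C)N2C(=O)[C@@H](C3Cc4ccccc4C3)NC(=O)[C@H]2CC(C)C)c(C)o1` has not yet been measured. It differs from compound 2 in a single place: 2,5-dimethyl-1,3-oxazol-4-yl in place of 2-methyl-1,3-thiazol-4-yl on a saturated chain carbon bound to an amide-type nitrogen in a ring and a carbonyl carbon. Both groups are small five-membered aromatic rings carrying methyl groups, and the rest of the molecule is unchanged. Going by the values given here, no measured pair in this set shows the effect of such a swap, so no step can be borrowed from the data; a change of this kind is expected to shift the number little, if at all, beyond the scatter. Compound 3 is therefore estimated at 0.6 nM, with a range from 0.2 nM to 2 nM, which corresponds to an expected step of a 1.5-fold higher number from compound 2 to compound 3 (0.18 log units; within the scatter).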

Compound 3, inhibition constant: 3.16 nM
Compound 3: middle estimate off by 5.3-fold (0.72 log units), on the low side; measured number above the stated range.
By their numbers in this assay, from the lowest: compound 2; then compound 3; then compound 1.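

The ring on this saturated chain carbon is not a freely exchangeable part of the molecule: in this assay the change gives a 7.9-fold higher number from compound 2 to compound 3 (0.90 log units; beyond the scatter), a step beyond the scatter, although both groups are five-membered aromatic rings that match in their counts of hetero atoms, hydrogen-bond donors and hydrogen-bond acceptors. Going by these compounds alone, compound 1 differs from the other two in more than one place, so this pair gives the first direct reading of how strongly the number responds to a change at this position alone, and it shows that even a swap between two similar small rings can be felt here. No measurement at hand explains why the number moves.

The change also alters two things at once, replacing the ring sulfur with oxygen and adding a methyl group, so the compounds shown leave open how much of the step belongs to each. A 2-methyl-1,3-oxazol-4-yl group, which has the oxygen without the added methyl, and a 2,5-dimethyl-1,3-thiazol-4-yl group, which has the added methyl with the sulfur, would separate the two.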